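Ring-swap notes: fluorophenyl to fluoropyridyl on the aryl arm

A few compounds are considered here, and "the series" means these few. Any claim that something is new, unique, unknown or untested is made for them only; others in the source may bear on it.

Measured so far in a functional assay on HT-29 cells (Homo sapiens) for inhibition, with a stated time of 72 h; on this read-out higher numbers stand for weaker inhibition and lower numbers for stronger inhibition:
- compound 1 `COc1ccc(S(=O)(=O)N2CCc3cccc(-c4cccnc4)c32)cc1`: 76.3 nM
- compound 2 `COc1ccc(S(=O)(=O)N2CCc3cccc(-c4ccc(F)cc4)c32)cc1`: 85.5 nM

Compound 2 has the highest of the two numbers, and its nearest neighbour is compound 1, with the pair within the scatter. Compound 3 `COc1ccc(S(=O)(=O)N2CCc3cccc(-c4ccc(F)nc4)c32)cc1` is not yet measured. The change: 6-fluoropyridin-3-yl in place of 4-fluorophenyl on an aromatic carbon. Among the compounds with values here, the one step that bears on it, a 1.1-fold higher number from compound 1 to compound 2 (0.05 log units; within the scatter), stayed within the scatter, so no step beyond the scatter is expected for compound 3 in this assay, which means a step of a 1.1-fold lower number from compound 2 to compound 3 (0.03 log units; within the scatter). The estimate for compound 3 is 80 nM, with a range from 40 nM to 160 nM.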

Compound 3, half-maximal inhibitory concentration: 109 nM
Compound 3: middle estimate off by 1.4-fold (0.13 log units), on the low side; low and high end bracket the measured number.
By their numbers in this assay, from the lowest: compounds 1, 2 and 3 (each within the scatter of the next).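

In this assay, the 6-fluoropyridin-3-yl arm is tolerated on this aromatic carbon in place of 4-fluorophenyl, with a 1.3-fold higher number from compound 2 to compound 3 (0.11 log units; within the scatter) as the step, so a ring nitrogen added to the fluorinated arm does not separate the two. Fluoro in place of hydrogen on the pyridin-3-yl arm gives a 1.4-fold higher number from compound 1 to compound 3 (0.15 log units; within the scatter) as its step and likewise separates nothing on this read-out. No measurement at hand offers a reason for either step.

Open, from the compounds shown here alone, is whether any group on this arm moves the number beyond the scatter, for instance an amine, a carboxylic acid or a methoxy group in place of the fluoro.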